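Swapping Chloro for Ethoxy in Compound 1

This account rests on a few compounds, and the source may have more. Where it says the series, first, only, none or still open, it means among the compounds named here.

compound 1 `COc1cc(Sc2c[nH]c3ccc(Cl)cc23)cc(OC)c1OC`: 77 nM
compound 2 `COc1cc(Sc2c(C)[nH]c3ccc(Cl)cc23)cc(OC)c1OC`: 82 nM
compound 3 `COc1cc(Sc2c[nH]c3ccc(N)cc23)cc(OC)c1OC`: 260 nM

In a functional assay on MCF7 cells (Homo sapiens) for inhibition, with a stated time of 48 h (on this read-out higher numbers stand for weaker inhibition and lower numbers for stronger inhibition), compound 1 gives 77 nM, the lowest number of the three, though compound 2 cannot be told apart from it. Putting methyl in place of hydrogen gave a 1.1-fold higher number from compound 1 to compound 2 (0.03 log units; within the scatter). Putting amino in place of chloro gave a 3.4-fold higher number from compound 1 to compound 3 (0.53 log units; beyond the scatter).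

The next compound is compound 4 `CCOc1ccc2[nH]cc(Sc3cc(OC)c(OC)c(OC)c3)c2c1`, which keeps the core of compound 1 but differs by ethoxy in place of chloro on an aromatic carbon. The methyl step was made elsewhere on the molecule and says little here. The amino step is the only measured one that also removes the chloro, so it is the closest guide, though amino is not ethoxy and a single step is thin evidence. A modest rise in the number therefore seems likely, with no change also possible. The expected step is a 2.5-fold higher number from compound 1 to compound 4 (0.39 log units; beyond the scatter). For compound 4 the estimated value is 190 nM, with an expected range from 60 nM to 600 nM.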

Compound 4, half-maximal inhibitory concentration: 16 nM
Estimate against measurement, compound 4: 12-fold (1.07 log units) above, and the stated range ends above it.
By their numbers in this assay, from the lowest: compound 4; then compounds 1 and 2 (each within the scatter of the next); then compound 3.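

In this assay, replacing chloro at this position does not have to cost activity: ethoxy in place of chloro gave a 4.8-fold lower number from compound 1 to compound 4 (0.68 log units; beyond the scatter) and so moved the number the opposite way from the amino change. Comparing the two replacements directly, ethoxy in place of amino gave a 16-fold lower number from compound 3 to compound 4 (1.21 log units; beyond the scatter) on the same core, which shows that the outcome at this position depends strongly on which group is placed there. The data offer no independent measurement that explains these differences.

With only chloro, amino and ethoxy compared here, it remains unclear how the number would respond to a shorter methoxy group or a longer propoxy chain. An ethyl group at the same position would help show whether the oxygen of ethoxy matters or whether its carbon chain alone can give the same result.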